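The source may hold more compounds than are shown below. What is called first, only, known or untested is meant among the compounds shown, and "the series" means these compounds.

Measured in a functional assay on B16-F10 cells (Mus musculus) for antiproliferative activity, read by MTT assay, with a stated time of 48 h; a lower number here means a stronger inhibitor, a higher number a weaker inhibitor
compound 1 `COc1ccc(C2OC(c3ccc4ccccc4c3)=NN2C(C)=O)cc1` gives 6.86 ug/mL
compound 2 `CC(=O)N1N=C(c2ccc3ccccc3c2)OC1c1ccccc1O` gives 2.58 ug/mL
compound 3 `CC(=O)N1N=C(c2ccc3ccccc3c2)OC1c1ccncc1` gives 2.97 ug/mL

Compound 1 stands highest of the three, and both steps away from it lie beyond the scatter but are modest (a 2.7-fold lower number from compound 1 to compound 2 (0.42 log units; beyond the scatter); a 2.3-fold lower number from compound 1 to compound 3 (0.36 log units; beyond the scatter)). Compounds 2 and 3 cannot be told apart (a 1.2-fold higher number from compound 2 to compound 3 (0.06 log units; within the scatter)).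

Next is compound 4 `CC(=O)N1N=C(c2ccc3ccccc3c2)OC1c1ccc(OCc2ccccc2)cc1`, where methoxy on compound 1 becomes benzyloxy (phenyl in place of hydrogen on a saturated chain carbon bound to an oxygen on an aromatic ring). Within the data shown here, no measured step makes this change. The three steps available all replace the whole 4-methoxyphenyl on a saturated ring carbon, so they bear on it only indirectly. They suggest that large swings are not the norm in this small set, though three compounds are a thin basis. Both steps from compound 1 lead to lower numbers (a 2.7-fold lower number from compound 1 to compound 2 (0.42 log units; beyond the scatter); a 2.3-fold lower number from compound 1 to compound 3 (0.36 log units; beyond the scatter)), but neither adds a phenyl, so they give only a faint lean in direction. No step beyond the scatter is therefore expected in this assay, and the range is kept wide on both sides. The estimated change is a 1.1-fold lower number from compound 1 to compound 4 (0.06 log units; within the scatter) and it is expected to stay small. The estimated value for compound 4 is 6 ug/mL (2.5 ug/mL to 15 ug/mL) and remains to be tested.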

Compound 4, half-maximal inhibitory concentration: 8.08 ug/mL
For compound 4 the middle estimate is 1.3-fold (0.13 log units) below the measured one; measured number inside the range.
By their numbers in this assay, from the lowest: compounds 2 and 3 (each within the scatter of the next); then compounds 1 and 4 (each within the scatter of the next).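

In this assay, among these compounds, the change from methoxy to benzyloxy gives a 1.2-fold higher number from compound 1 to compound 4 (0.07 log units; within the scatter), the first direct reading of phenyl in place of hydrogen on a saturated chain carbon bound to an oxygen on an aromatic ring. The earlier steps shown here replaced the whole 4-methoxyphenyl on a saturated ring carbon, whereas this one keeps that aromatic ring and its oxygen and alters only the chain beyond them, and the added phenyl produces no change that can be read beyond the scatter. No supporting measurement bears on this result, so the flat step stands as an observation without an explanation.

Still open, on these data alone, is whether a different group at this place, such as an amine or a carboxylic acid, or a longer chain carrying the phenyl, would move the number beyond the scatter. A single step also leaves open whether substituents on the added phenyl, such as chlorine or methoxy, would matter, and whether the same addition would read alike on other members of the series.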